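This account rests on a few compounds, and the source may have more. Where it says the series, first, only, none or still open, it means among the compounds named here.

Measured compounds:
compound 1 `Fc1cccc(-c2nc(Nc3ccccc3Br)c3cc(F)ccc3n2)c1` — > 50000 nM
compound 2 `Nc1ccc(Nc2nc(-c3cccc(F)c3)nc3ccc(F)cc23)cc1` — > 50000 nM

In a functional assay on U-937 cells (Homo sapiens) for cytotoxicity, read by MTT assay, with a stated time of 48 h (a lower number here means a stronger inhibitor, a higher number a weaker inhibitor), compound 1 reaches only the limit of the assay, > 50000 nM being a limit and not a number. Compound 2 likewise gives only a limit in this assay, > 50000 nM. Within the data shown here, the step that the two limits leave unreadable from compound 1 to compound 2 therefore cannot be read in size or direction, and this is the only measured step; the limit of > 50000 nM in this assay, at which 2 of the 2 values shown sit, records where both measured values sit.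

Compound 3 `Nc1ccccc1Nc1nc(-c2cccc(F)c2)nc2ccc(F)cc12` differs from compound 2 by 2-aminophenyl in place of 4-aminophenyl on a nitrogen on an aromatic ring. Among the measured compounds shown here, no measured step bears on this change, since the one step available is unreadable, so nothing in the data points to a gain or loss in this assay. The expectation is that compound 3 also stays at the limit, with the estimate 50000 nM spanning 15000 nM to 50000 nM, and the expected step of a number no higher from compound 2 to compound 3 (the limit leaves the size open) is essentially none that could be read.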

Compound 3, half-maximal inhibitory concentration: 47300 nM
For compound 3 the middle estimate is 1.1-fold (0.02 log units) above the measured one, and the stated range covers the measured number.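

Of the three compounds, compound 3 alone gives a number rather than a limit in this assay, so 2-aminophenyl on this nitrogen brings the reading within the range of the assay, where 4-aminophenyl and 2-bromophenyl do not. Placing 2-aminophenyl in the position of 4-aminophenyl gives an at least 1.0-fold lower number from compound 2 to compound 3 (0.02 log units; that floor lies within the scatter), and amino in place of bromo on an aromatic carbon gives an at least 1.0-fold lower number from compound 1 to compound 3 (0.02 log units; that floor lies within the scatter). Neither step can be sized beyond these floors, and the data show no change beyond the scatter, with the other values still at a limit: the limit of > 50000 nM in this assay, at which 2 of the 3 values shown sit.

The compounds shown leave open how far either step truly reaches. They also leave open whether a hydroxyl or a carboxylic acid in place of the amino of 2-aminophenyl would give a clearly lower number.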